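Removing the polar substituent from the piperidine of compound 3

The source may hold more compounds than are shown below. What is called first, only, known or untested is meant among the compounds shown, and "the series" means these compounds.

The three measured compounds share one core and differ only in the group on the piperidine. Compound 1 `OC1CCN(c2ncnc3[nH]cc(-c4cccc(Cl)c4)c23)CC1` gives 80 nM in an assay for inhibition of serine/threonine-protein kinase 4 (Homo sapiens), read by luminescence and ADP-Glo, in the presence of a further agent that is not named here; a lower number here means a stronger inhibitor, a higher number a weaker inhibitor. Compound 2 `CNC1CCN(c2ncnc3[nH]cc(-c4cccc(Cl)c4)c23)CC1` gives 148 nM, and compound 3 `CC1(N)CCN(c2ncnc3[nH]cc(-c4cccc(Cl)c4)c23)CC1` gives 163 nM. Among these numbers compound 3 stands highest, with compound 2 nearest and compound 1 furthest; the step of a 1.1-fold higher number from compound 2 to compound 3 (0.04 log units; within the scatter) lies within the scatter, while the step of a 2.0-fold higher number from compound 1 to compound 3 (0.31 log units; beyond the scatter) is modest but beyond it, and the step of a 1.9-fold higher number from compound 1 to compound 2 (0.27 log units; within the scatter) is within the scatter.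

Compound 4 `Clc1cccc(-c2c[nH]c3ncnc(N4CCCCC4)c23)c1` differs from compound 3 in one place: piperidin-1-yl in place of 4-amino-4-methylpiperidin-1-yl on an aromatic carbon. The measured steps all swap one polar group on the saturated ring for another and stay small; none removes the polar group altogether, so the bearing of a 2.0-fold higher number from compound 1 to compound 3 (0.31 log units; beyond the scatter) and a 1.1-fold higher number from compound 2 to compound 3 (0.04 log units; within the scatter) on this change is only indirect. Given that every exchange so far moved the number little, the expected step of a 1.3-fold higher number from compound 3 to compound 4 (0.13 log units; within the scatter) in this assay is small to modest toward a higher number, with wide uncertainty. Compound 4 is therefore expected to give about 220 nM, within a range from 70 nM to 700 nM.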

Compound 4, half-maximal inhibitory concentration: 48 nM
The estimate for compound 4 lay 4.6-fold (0.66 log units) above the measured number; measured number outside the range, below it.
By their numbers in this assay, from the lowest: compounds 4, 1, 2 and 3 (each within the scatter of the next, the first and the last beyond it).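

In this assay, removing the substituent from the piperidine altogether costs nothing at this aromatic carbon, which the earlier exchanges of one substituent for another could not show: the change gives a 3.4-fold lower number from compound 3 to compound 4 (0.53 log units; beyond the scatter) and, with hydrogen replacing methylamino on the saturated ring carbon, a 3.1-fold lower number from compound 2 to compound 4 (0.49 log units; beyond the scatter). Hydroxy behaves differently, since hydrogen in its place gives a 1.7-fold lower number from compound 1 to compound 4 (0.22 log units; within the scatter), so among these compounds the plain piperidin-1-yl is separated from the two amine-bearing groups of compound 2 and compound 3 but not from the 4-hydroxypiperidin-1-yl of compound 1. Nothing measured here accounts for these differences.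

Going by these compounds, it remains open whether the amine itself goes with the higher numbers, a question that 4-aminopiperidin-1-yl would bear on by separating the amine from the methyl group that shares its ring carbon in compound 3. On these data alone, it is also open whether a carbon-only substituent such as 4-methylpiperidin-1-yl, or a change to the ring itself such as pyrrolidin-1-yl or morpholin-4-yl, would stay close to compound 4 at 48 nM in this assay or move away from it.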